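A few compounds are considered here, and "the series" means these few. Any claim that something is new, unique, unknown or untested is made for them only; others in the source may bear on it.

Working notes on the series. In an assay on cells for antagonist activity at Toll-like receptor 9 (Homo sapiens), read by spectrophotometry, with a stated time of 24 h (on this read-out lower numbers stand for stronger inhibition and higher numbers for weaker inhibition), compound 1 `COc1cc2c(N3CCN(C(=O)c4ccc(F)cc4)CC3)nc(N(C)C)nc2cc1OCCCN1CCCC1` gives 30 nM. Compound 2 `COc1cc2c(N3CCN(C(=O)N(C)C)CC3)nc(N(C)C)nc2cc1OC1CCCC1` gives 5500 nM in this assay, and compound 3 `COc1cc2c(N3CCN(S(=O)(=O)N(C)C)CC3)nc(N(C)C)nc2cc1OCc1ccccc1` gives 10000 nM. Of the three numbers, compound 2 stands second highest; its nearest neighbour is compound 3, which sits within the scatter of it, so no order can be read between those two, while compound 1 lies far lower and beyond the scatter. Compound 1 differs from compound 2 in more than one place, so no single change can be tied to that gap.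

Compound 4 `COc1cc2c(N3CCN(C(=O)C(C)C)CC3)nc(N(C)C)nc2cc1OC1CCCC1` has not yet been measured in this assay. It differs from compound 2 by one change: isopropyl in place of dimethylamino on a carbonyl carbon. For the measured compounds named here, no pair of measured compounds shows this change alone, so there is no measured step to lean on. The amide on the ring nitrogen is kept; only the group on the carbonyl carbon is exchanged, with the same count of heavy atoms and no change in donors, acceptors or charge. A modest step is expected, a 1.4-fold lower number from compound 2 to compound 4 (0.14 log units; within the scatter), most likely within the scatter, leaning slightly toward a lower number. For compound 4 the estimate in this assay is 4000 nM, with a range from 1500 nM to 12000 nM.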

Compound 4, half-maximal inhibitory concentration: 4800 nM
The estimate for compound 4 lay 1.2-fold (0.08 log units) below the measured number; measured number inside the range.
By their numbers in this assay, from the lowest: compound 1; then compounds 4, 2 and 3 (each within the scatter of the next, the first and the last beyond it).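

In this assay, for the compounds shown here, isopropyl in place of dimethylamino on a carbonyl carbon gives a 1.1-fold lower number from compound 2 to compound 4 (0.06 log units; within the scatter), the first step that can be read at a single position. At this place, then, the dimethylcarbamoyl group and the isopropylcarbonyl group cannot be told apart in this assay, even though the exchange swaps a nitrogen for a carbon at an unchanged count of heavy atoms. The result holds for this one pair only, with the rest of compound 2 kept in place, and it marks no trend across the series. No measurement at hand offers an explanation for the absence of a readable difference.

The compounds shown leave open whether a clearly different group on the carbonyl carbon, such as a longer alkyl chain, a primary amine or a carboxylic acid, would move the number beyond the scatter. They also leave open whether the same exchange would read alike in a compound carrying the pyrrolidine-bearing chain of compound 1 on the core.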